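Replacing a Thienyl Ketone with an Indolyl Ketone

The source may hold more compounds than are shown below. What is called first, only, known or untested is meant among the compounds shown, and "the series" means these compounds.

Measured compounds:
compound 1, `COc1ccc(-c2cc3ccccc3nc2/C=C/C(=O)c2ccc(F)cc2)cc1`: 6990 nM
compound 2, `COc1ccc(-c2cc3ccccc3nc2/C=C/C(=O)c2ccsc2)cc1`: 7080 nM

In a functional assay on NCI-H460 cells (Homo sapiens) for antiproliferative activity, read by XTT assay, with a stated time of 72 h (on this read-out lower numbers stand for stronger inhibition and higher numbers for weaker inhibition), compound 1 gives 6990 nM and compound 2 gives 7080 nM. For the measured compounds named here, the only measured step, a 1.0-fold higher number from compound 1 to compound 2 (0.01 log units; within the scatter), exchanges one aryl group on the carbonyl carbon for another without moving the number beyond the scatter. Going by the values given here, compound 2 therefore stands alongside compound 1, the only other measured compound, with nothing separating the two.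

Compound 3 `COc1ccc(-c2cc3ccccc3nc2/C=C/C(=O)c2c[nH]c3ccccc23)cc1` carries the change (1H-indol-3-yl in place of thiophen-3-yl on a carbonyl carbon). The measured step touches the same carbonyl carbon but concerns a different pair of groups, so it bears only loosely on the present change; it shows, at most, that swapping the aryl group at this position left the number where it was. Compound 3 is thus expected to stay close to compound 2, with an estimated step of a 1.2-fold lower number from compound 2 to compound 3 (0.07 log units; within the scatter). The estimate for compound 3 in this assay is 6000 nM, within 2500 nM to 15000 nM.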

Compound 3, half-maximal inhibitory concentration: 8010 nM
Estimate against measurement, compound 3: 1.3-fold (0.13 log units) below; low and high end bracket the measured number.
By their numbers in this assay, from the lowest: compounds 1, 2 and 3 (each within the scatter of the next).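

In this assay, the exchange of thiophen-3-yl for 1H-indol-3-yl, which brings a six-membered aromatic ring of carbon only and a hydrogen-bond donor, gives a step (a 1.1-fold higher number from compound 2 to compound 3 (0.05 log units; within the scatter)) that lies within the scatter. The exchange of 4-fluorophenyl for the same group gives a step (a 1.1-fold higher number from compound 1 to compound 3 (0.06 log units; within the scatter)) that also lies within the scatter, so three aryl groups of differing ring count on the carbonyl carbon now stand unseparated in this read-out. Nothing available here bears on why these groups give such similar numbers. The compounds shown leave open whether a non-aromatic group on the carbonyl carbon, such as an amine or a short alkyl chain, would separate from these three. They also leave open whether an aryl group carrying a carboxylic acid would do so.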